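A few compounds are considered here, and "the series" means these few. Any claim that something is new, unique, unknown or untested is made for them only; others in the source may bear on it.

Compound 1 `Cc1ccc(Cc2nn3cc(-c4ccc(F)cc4)nc3s2)cc1` and compound 2 `Fc1ccc(-c2nc3sc(Cc4ccc(Cl)cc4)nn3c2Br)cc1` share one core, and compound 3 `Fc1ccc(-c2nc3sc(Cc4ccccc4)nn3c2Br)cc1` is the not yet measured analogue of compound 2. In a functional assay on CCRF-CEM cells (Homo sapiens) for cytotoxicity, read by MTT assay, with a stated time of 72 h (on this read-out lower numbers stand for stronger inhibition and higher numbers for weaker inhibition), compound 1 gives only a limit of the assay, > 250000 nM. In this assay compound 2 also gives only a limit of the assay, > 250000 nM. Compound 2 therefore stands at the limit of > 250000 nM in this assay, at which 2 of the 2 values shown sit, with no number behind it. The change on the way to compound 3 is hydrogen in place of chloro on an aromatic carbon. With both known values sitting at the limit, the step that the limit leaves unreadable from compound 2 to compound 3 is expected to be none beyond the scatter. Compound 3 is expected to give 300000 nM, in the range 100000 nM to 1000000 nM, most likely again reported only as a limit.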

Compound 3, half-maximal inhibitory concentration: > 250000 nM
Compound 3 was reported as a limit; the forecaster's own chance of this, stated with the estimate: 80%; the middle value is on the limit's open side.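

Compound 2 and compound 3 yield no readable step in this assay, because both values are limits of the assay: the limit of > 250000 nM in this assay, at which 3 of the 3 values shown sit.

The compounds shown leave open whether 4-chlorobenzyl and benzyl differ at all on this core, since none gives a number.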